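Series notes: alkyl ethers on a shared aminoglycoside-type core

A few compounds are considered here, and "the series" means these few. Any claim that something is new, unique, unknown or untested is made for them only; others in the source may bear on it.

Three compounds of the series have been run in an ADME assay on J774 cells (Mus musculus) for cytotoxicity, read by MTT assay, with a stated time of 24 h, tested at 10 uM; on this read-out higher numbers stand for a weaker effect at the one concentration tested and lower numbers for a stronger effect. Compound 1 `CCCCCCCCCCCO[C@@H]1[C@@H](N)[C@@H](O[C@H]2[C@H](O)[C@@H](OCCCCCCC)[C@H](N)C[C@@H]2N)O[C@H](CN)[C@H]1O` gives 88.4% in this assay. Compound 2 `CCCCCCCCCO[C@@H]1[C@@H](N)[C@@H](O[C@H]2[C@H](O)[C@@H](OCCCCCCCCC)[C@H](N)C[C@@H]2N)O[C@H](CN)[C@H]1O` gives 86.7%, and compound 3 `NC[C@H]1O[C@H](O[C@H]2[C@H](O)[C@@H](O)[C@H](N)C[C@@H]2N)[C@H](N)[C@@H](OCCCc2ccc3ccccc3c2)[C@@H]1OCCCc1ccc2ccccc2c1` gives 87.7%. The three numbers differ by less than the usual scatter of the measurement, so compound 1 cannot be set apart from compound 2 or compound 3 on this read-out; all three sit close together at the weak-effect end of the scale.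

Compound 4 `CCCCCCCO[C@@H]1[C@@H](O)[C@H](O[C@H]2O[C@H](CN)[C@@H](O)[C@H](O)[C@H]2N)[C@@H](N)C[C@H]1N` has not yet been run in this assay. Against compound 1 the change is hydrogen in place of undecyl on an oxygen on a saturated carbon. Cut one bond further out, the change reads undecyloxy to hydroxy, with no ring, donor or acceptor leaving with the undecyl group.

Within the data shown here, no pair of measured compounds differs in one place, so no step size is known from the data. Given that compound 1, compound 2 and compound 3 all fall within the scatter of each other despite differing chains, the step from compound 1 to compound 4 is expected to stay within the scatter, with no clear direction, and a number 1.6 percentage points higher from compound 1 to compound 4 (within the scatter) is the estimated step. Compound 4 is expected to give 90% in this assay, within a range from 78% to 100%.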

Compound 4, a percentage reported as activity, at one concentration (the size of the read-out at that concentration, not a potency): 84.3%
For compound 4 the middle estimate is 5.7 percentage points above the measured one, within the range that was stated.
By their numbers in this assay, from the lowest: compounds 4, 2, 3 and 1 (each within the scatter of the next).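

Among these compounds, the undecyloxy to hydroxy change gives the first step that can be read at a single place in this assay, a number 4.1 percentage points lower from compound 1 to compound 4 (within the scatter). Among the compounds shown here, the undecyl group on this oxygen on a saturated carbon can therefore be replaced by hydrogen without a shift that stands clear of the scatter, whereas the earlier compounds differed in more than one place and could not isolate this position. No measurement shown bears on why the step has this size.

On these data alone, whether a shorter chain such as ethyl, a benzyl ether or an amine at this position would also leave the read-out within the scatter of compound 1 remains open, as one step at one position gives no trend across groups. Compound 4 still carries a heptyl ether, so the result says nothing about a compound with no ether chain at all, and a reading at a single concentration leaves open how the series behaves at higher concentrations.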